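A Second Chloro Group Added to Compound 1

A few compounds are considered here, and "the series" means these few. Any claim that something is new, unique, unknown or untested is made for them only; others in the source may bear on it.

Compound 1 `O=[N+]([O-])c1cc(-c2nnn(Cc3ccc(Cl)cc3)n2)cc([N+](=O)[O-])c1` gives 170000 nM in an ADME assay on CHO-K1 cells (Cricetulus griseus) for cytotoxicity, read by MTT assay, with a stated time of 24 h (a lower number here means a stronger inhibitor, a higher number a weaker inhibitor), the highest of the two numbers measured. Compound 2 `COc1ccc(Cn2nnc(-c3cc([N+](=O)[O-])cc([N+](=O)[O-])c3)n2)cc1` gives 96000 nM in this assay, and a 1.8-fold lower number from compound 1 to compound 2 (0.25 log units; within the scatter). For compound 3 `COc1cccc(Cn2nnc(-c3cc([N+](=O)[O-])cc([N+](=O)[O-])c3)n2)c1` only a limit of > 100000 nM is recorded in this assay. The step that the limit leaves unreadable from compound 1 to compound 3 is therefore not readable, and an at least 1.0-fold higher number from compound 2 to compound 3 (0.01 log units; that floor lies within the scatter) (the limit of > 100000 nM in this assay, at which 1 of the 3 values shown sits). Compound 4 `O=[N+]([O-])c1cc(-c2nnn(Cc3ccc(Cl)c(Cl)c3)n2)cc([N+](=O)[O-])c1` differs from compound 1 by chloro in place of hydrogen on an aromatic carbon. For the measured compounds named here, no measured step adds a chloro group; the one readable step exchanges chloro for methoxy and stays within the scatter, so in this assay no step beyond the scatter is expected. Compound 4 is expected to give 170000 nM, between 80000 nM and 350000 nM. That estimate for compound 4 means no change at the digits printed from compound 1 to compound 4 (within the scatter).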

Compound 4, half-maximal inhibitory concentration: 37000 nM
Estimate against measurement, compound 4: 4.6-fold (0.66 log units) above; the whole stated range lies above it.
By their numbers in this assay, from the lowest: compound 4; then compounds 2 and 1 (each within the scatter of the next).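

In this assay, for the compounds shown here, chloro on the aromatic carbon ortho to the chloro group, which turns 4-chlorophenyl into 3,4-dichlorophenyl, gives the first step beyond the scatter: a 4.6-fold lower number from compound 1 to compound 4 (0.66 log units; beyond the scatter). The 3,4-dichlorophenyl group also separates compound 4 from the methoxy compounds, with a 2.6-fold lower number from compound 2 to compound 4 (0.41 log units; beyond the scatter) and an at least 2.7-fold lower number from compound 3 to compound 4 (0.43 log units; beyond the scatter). Compound 3 holds a limit and not a number: the limit of > 100000 nM in this assay, at which 1 of the 4 values shown sits.

On these data alone, whether fluoro, methyl or trifluoromethyl at this position would give a similar step remains open. So does whether the step would persist with amines in place of the nitro groups.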